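The source may hold more compounds than are shown below. What is called first, only, known or untested is meant among the compounds shown, and "the series" means these compounds.

Measured compounds in an ADME assay on microsomes from liver (Rattus norvegicus), read by LC-MS, using NADPH, with a stated time of 30 min, tested at 1 uM; a higher number here means that more of the compound is left, a lower number that less of the compound is left:
- compound 2 `C[C@H](Nc1nc(N)nc(N)c1C#N)c1c(-c2ccccc2)c(=O)n2cc(F)ccc2c1-c1ccccc1`: 73%
- compound 3 `COc1ccc(-c2c([C@H](C)Nc3nc(N)nc(N)c3C#N)c(-c3ccccc3)c(=O)n3cc(F)ccc23)cc1`: 76%
- compound 1 `C[C@H](Nc1nc(N)nc(N)c1C#N)c1cc(=O)n2cc(F)ccc2c1-c1ccc(F)cc1`: "not determined" (no result reported)

Compound 3 stands highest of the two numbers, though the gap to compound 2 is within the scatter: the step of a number 3 percentage points higher from compound 2 to compound 3 (within the scatter), a methoxy in place of hydrogen on an aromatic carbon, changed nothing beyond the usual spread. Compound 1, which carries a fluorophenyl group on the same core, gives no number that could be used here.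

Compound 4 `C[C@H](Nc1nc(N)nc(N)c1C#N)c1c(-c2ccccc2)c(=O)n2cc(F)ccc2c1-c1ccc(F)cc1` differs from compound 3 by fluoro in place of methoxy on an aromatic carbon. Among the measured compounds shown here, no measured step covers a fluoro in place of methoxy; the only measured step on this position, from compound 2 to compound 3, was within the scatter, so the position so far appears insensitive in this assay. On that basis the step of a number 1 percentage points lower from compound 3 to compound 4 (within the scatter) is expected to stay within the scatter, with no clear direction. For compound 4 the estimate in this assay is 75%, in the range 55% to 90%.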

Compound 4, percent of the compound remaining: 77%
For compound 4 the middle estimate is 2 percentage points below the measured one, within the range that was stated.
By their numbers in this assay, from the lowest: compounds 2, 3 and 4 (each within the scatter of the next).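

In this assay, the step of a number 1 percentage points higher from compound 3 to compound 4 (within the scatter), with fluoro in place of methoxy, shows that 4-methoxyphenyl and 4-fluorophenyl read alike at this place. Among the compounds shown here, the step of a number 4 percentage points higher from compound 2 to compound 4 (within the scatter) adds fluoro in place of hydrogen, so hydrogen, methoxy and fluoro on this aromatic carbon, para to a large group, now all lie within the scatter of one another, a flat reading that holds for compounds 2, 3 and 4 and rests on more than the single earlier step. No available measurement speaks to the reason for this flat reading.

On these data alone, whether an amine or a carboxylic acid on this aromatic carbon would stay within the scatter remains open. Compound 1 gives "not determined" (no result reported), so the contribution of the phenyl group that compound 4 carries and compound 1 lacks cannot be read.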